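Adding a methyl to the chain amine of compound 3

The source may hold more compounds than are shown below. What is called first, only, known or untested is meant among the compounds shown, and "the series" means these compounds.

Three compounds share one core. In a functional assay on HEK293 cells for agonist activity at 5-hydroxytryptamine receptor 7 (Homo sapiens), read by cAMP accumulation, with a stated time of 30 min (on this read-out higher numbers stand for larger maximal responses and lower numbers for smaller maximal responses), compound 1 `COc1ccccc1-c1cc(C2CCNC2)ccc1Cl` gives 29%, compound 2 `COc1ccccc1-c1cc(C2CCN(C)C2)ccc1Cl` gives 9.8% and compound 3 `CNCc1ccc(Cl)c(-c2ccccc2OC)c1` gives 72%. Compound 3 thus stands highest of the three: the change a number 43 percentage points higher from compound 1 to compound 3 (beyond the scatter) and the change a number 62.2 percentage points higher from compound 2 to compound 3 (beyond the scatter) are both large. Compound 4 `COc1ccccc1-c1cc(CN(C)C)ccc1Cl` differs from compound 3 only by methyl in place of hydrogen on an amine nitrogen. Going by the values given here, the one measured step of the same kind, a number 19.2 percentage points lower from compound 1 to compound 2 (beyond the scatter), was a modest drop, although there the amine nitrogen sat in a ring. A similar drop is therefore expected, so that the step of a number 22 percentage points lower from compound 3 to compound 4 (beyond the scatter) is the estimate. For compound 4 the expected value in this assay is 50%, estimated to lie between 25% and 75%.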

Compound 4, largest response reached (Emax), in percent of the reference or control that the assay uses: 11%
For compound 4 the middle estimate is 39 percentage points above the measured one; the measured number lies below the stated range.
By their numbers in this assay, from the lowest: compounds 2 and 4 (each within the scatter of the next); then compound 1; then compound 3.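

In this assay, methyl in place of hydrogen on an amine nitrogen whose other neighbours are saturated chain carbons gives a large step (a number 61 percentage points lower from compound 3 to compound 4 (beyond the scatter)), where the ring nitrogen gave only a modest one (a number 19.2 percentage points lower from compound 1 to compound 2 (beyond the scatter)). The high value of compound 3 therefore depends on that hydrogen. The edge of the chain over the ring disappears once the nitrogen is methylated (a number 1.2 percentage points higher from compound 2 to compound 4 (within the scatter)), and the chain compound now sits under the ring compound that still has its hydrogen (a number 18 percentage points lower from compound 1 to compound 4 (beyond the scatter)).

No evidence here explains the size of this loss. Going by these compounds, how a primary amine or an ethyl group on this nitrogen would behave remains open.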